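The source may report more compounds than this note shows. Statements on the series, on what has been measured and on what is new or still open speak of the compounds shown alone.

Compounds measured so far in a functional assay on MCF7 cells (Homo sapiens) for antiproliferative activity, read by MTT assay, with stated times of 24 h and 72 h; on this read-out lower numbers stand for stronger inhibition and higher numbers for weaker inhibition:

- compound 1, `COc1cc(N2C(=O)[C@@H](Oc3ccccc3)[C@H]2c2cccc([N+](=O)[O-])c2)cc(OC)c1OC`: 30000 nM
- compound 2, `COc1cc(N2C(=O)[C@@H](Oc3ccccc3)[C@H]2c2ccc(SC)cc2)cc(OC)c1OC`: 7700 nM
- compound 3, `COc1cc(N2C(=O)[C@@H](Oc3ccccc3)[C@H]2c2ccc(S(C)(=O)=O)cc2)cc(OC)c1OC`: 62000 nM

Compound 3 gives the highest number of the three. Its nearest neighbour is compound 1, since a 2.1-fold higher number from compound 1 to compound 3 (0.32 log units; beyond the scatter); compound 2 lies furthest from it, since an 8.1-fold higher number from compound 2 to compound 3 (0.91 log units; beyond the scatter). The third comparison, a 3.9-fold lower number from compound 1 to compound 2 (0.59 log units; beyond the scatter), completes the picture: changing the aryl group on the saturated ring carbon has moved this assay's read-out in both directions, and the whole set stays within a narrow band.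

Compound 4, `COc1ccc([C@@H]2[C@H](Oc3ccccc3)C(=O)N2c2cc(OC)c(OC)c(OC)c2)c(N)c1O`, is not yet measured. It differs from compound 3 as follows: a group of 10 heavy atoms (7 carbon, 1 nitrogen, 2 oxygen; one six-membered aromatic ring of carbon only) in place of a group of 10 heavy atoms (7 carbon, 2 oxygen, 1 sulfur; one six-membered aromatic ring of carbon only), on a saturated ring carbon

For the measured compounds named here, no measured step involves the entering group, so none bears directly on this change; the three steps above only show how much room the aryl group has to shift the number. Since compound 3 already stands at the top, and since swaps of this aryl group have moved the read-out by an 8.1-fold higher number from compound 2 to compound 3 (0.91 log units; beyond the scatter) at most, the expected step is a 3.1-fold lower number from compound 3 to compound 4 (0.49 log units; beyond the scatter), a modest move toward lower numbers, with wide uncertainty. Compound 4 is therefore expected to give about 20000 nM in this assay, in the range 5000 nM to 80000 nM.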

Compound 4, half-maximal inhibitory concentration: 19000 nM
Estimate against measurement, compound 4: 1.1-fold (0.02 log units) above, within the range that was stated.
By their numbers in this assay, from the lowest: compound 2; then compounds 4 and 1 (each within the scatter of the next); then compound 3.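

Placing this new aryl group on the saturated ring carbon brings hydrogen-bond donors to a position where 4-(methylsulfonyl)phenyl has none, and in this assay the swap gives a 3.3-fold lower number from compound 3 to compound 4 (0.51 log units; beyond the scatter) as its measured effect. Those donors do not carry the number past the one set by 4-(methylsulfanyl)phenyl, since the comparison shows a 2.5-fold higher number from compound 2 to compound 4 (0.39 log units; beyond the scatter) and leaves compound 2 with the lowest number of the four, beyond the scatter of each other compound. The new group also cannot be told apart from 3-nitrophenyl, as the record reads a 1.6-fold lower number from compound 1 to compound 4 (0.20 log units; within the scatter) for that exchange, so two aryl groups with quite different atoms now sit level at this position.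

Which of the amino, hydroxyl and methoxy groups on the new ring matters stays open, since all three enter together in a single step. As far as these compounds go, how a ring bearing a carboxylic acid would stand against compound 2 is equally open, as is any change to the phenoxy group, which is the same in all four compounds. Nothing measured here gives a reason for any of these steps.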